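A few compounds are considered here, and "the series" means these few. Any claim that something is new, unique, unknown or untested is made for them only; others in the source may bear on it.

Measured so far in a functional assay on HCT-15 cells (Homo sapiens) for inhibition, read by sulforhodamine B assay, with a stated time of 48 h; on this read-out lower numbers stand for higher toxicity in this test and higher numbers for lower toxicity in this test:
compound 1 `COc1cc(-c2nn(-c3cccc(NC(=O)Nc4cc(C(F)(F)F)cc(C(F)(F)F)c4)c3)cc2-c2ccncc2)ccc1Cl`: 4330 nM
compound 2 `O=C(Nc1cccc(-n2cc(-c3ccncc3)c(-c3ccc(Cl)c(O)c3)n2)c1)Nc1cc(C(F)(F)F)cc(C(F)(F)F)c1`: 21200 nM
compound 3 `COc1cc(-c2nn(-c3cccc(NC(=O)Nc4ccc(Cl)c(C(F)(F)F)c4)c3)cc2-c2ccncc2)ccc1Cl`: for compound 3 only a limit is reported, > 32500 nM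

Compound 1 and compound 2 share one core and differ in a single place, (hydrogen in place of methyl on an oxygen on an aromatic ring). In this assay the change gives a 4.9-fold higher number from compound 1 to compound 2 (0.69 log units; beyond the scatter), so the number moves upward. Compound 3 is built on a different urea part than compound 1; the difference between the two cores is not broken down here. For compound 3 the result in this assay is a limit and not a number: the limit of > 32500 nM in this assay, at which 1 of the 3 values shown sits.

Compound 4 `O=C(Nc1cccc(-n2cc(-c3ccncc3)c(-c3ccc(Cl)c(O)c3)n2)c1)Nc1ccc(Cl)c(C(F)(F)F)c1` has not been measured. It stands to compound 3 as compound 2 stands to compound 1, carrying (hydrogen in place of methyl on an oxygen on an aromatic ring); the place is described in the same words for both pairs, so this is the same change. For the measured compounds named here, the only measured instance of it, a 4.9-fold higher number from compound 1 to compound 2 (0.69 log units; beyond the scatter), raised the number, and compound 3 already gives only a limit. The step from compound 3 to compound 4 is therefore expected to be a step that the limit leaves unreadable from compound 3 to compound 4 or, more likely, to remain unresolved as a limit. Compound 4 is estimated at 60000 nM in this assay. The range expected for compound 4 runs from 30000 nM to 150000 nM, with a limit rather than a number being the most probable report.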

Compound 4, concentration lethal to 50% of the cells: > 32500 nM
Compound 4: a limit, no number; the forecaster's own chance of this, stated with the estimate: 85%; the middle value does not contradict the limit.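

Compound 3 is reported in this assay only as a limit, and compound 4 is likewise a limit, > 32500 nM, so no step can be read between the two. The compounds shown leave open how far the change from methoxy to hydroxy moves the number on the urea part of compound 3, and whether it matches a 4.9-fold higher number from compound 1 to compound 2 (0.69 log units; beyond the scatter).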